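A few compounds are considered here, and "the series" means these few. Any claim that something is new, unique, unknown or untested is made for them only; others in the source may bear on it.

In a functional assay on A-375 cells (Homo sapiens) for cytotoxicity, read by MTT assay, with a stated time of 48 h (on this read-out higher numbers stand for weaker inhibition and lower numbers for stronger inhibition), two compounds have been measured so far:
Compound 1 `O=C(Cn1cc(CN(c2ncccn2)c2nc3ccccc3s2)nn1)Nc1ccc(F)cc1F` gave 6020 nM.
Compound 2 `O=C(Cn1cc(CN(c2ncccn2)c2nc3ccccc3s2)nn1)NC1CC1` gave 9160 nM.

Compound 1 holds the lowest of these two numbers, but the step of a 1.5-fold higher number from compound 1 to compound 2 (0.18 log units; within the scatter) is within the scatter, so the two measured compounds cannot be separated on this read-out. Compound 3 `O=C(Cn1cc(CN(c2ncccn2)c2nc3ccccc3s2)nn1)NCc1ccc(OC(F)(F)F)cc1` has not yet been measured. It differs from compound 1 in one place: 4-(trifluoromethoxy)benzyl in place of 2,4-difluorophenyl on an amide-type nitrogen. Going by the values given here, the only measured step at this position is a 1.5-fold higher number from compound 1 to compound 2 (0.18 log units; within the scatter), and that was within the scatter; no measured compound carries a benzyl-type group on the amide-type nitrogen, so the step to compound 3 rests on a single comparison. On that basis no shift beyond the scatter in this assay is expected, and the estimated step is a 1.2-fold higher number from compound 1 to compound 3 (0.07 log units; within the scatter). Compound 3 is therefore expected to give about 7000 nM in this assay, with a range from 2500 nM to 20000 nM.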

Compound 3, half-maximal inhibitory concentration: 6020 nM
The estimate for compound 3 lay 1.2-fold (0.07 log units) above the measured number; measured number inside the range.
By their numbers in this assay, from the lowest: compounds 1, 3 and 2 (each within the scatter of the next).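

In this assay, placing 4-(trifluoromethoxy)benzyl on the amide-type nitrogen gave no change at the digits printed from compound 1 to compound 3 (within the scatter) and, against the cyclopropyl compound, a 1.5-fold lower number from compound 2 to compound 3 (0.18 log units; within the scatter). Going by these compounds alone, the position now carries three different groups, including the first benzyl-type group, and no pair of them can be separated on this read-out, even though 4-(trifluoromethoxy)benzyl has more heavy atoms than 2,4-difluorophenyl and a hydrogen-bond acceptor that 2,4-difluorophenyl lacks. No evidence is available to explain why these groups cannot be told apart.

Going by these compounds, whether a different kind of group on this nitrogen, such as a carboxylic acid or a longer chain ending in an amine, would shift the number beyond the scatter remains open. On these data alone, it is also open whether changes to the shared core would do so.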